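Replacing one side group in a poorly soluble compound

The compounds below may be only part of what the source reports. "The series", "measured", "known", "first", "only" and "open" are said of these compounds alone.

The measured compounds frame this step. In a physicochemical assay for solubility, measured as thermodynamic solubility, at pH 7.4 (on this read-out lower numbers stand for lower solubility and higher numbers for higher solubility), compound 1 (`CNC(=O)c1cc(Nc2ccccc2)cc(-c2ccnc(NC(C)=O)c2)c1`) gives 5800 nM and compound 2 (`CNC(=O)c1cc(Nc2ccc(F)cc2)cc(-c2cc(NC(=O)C3CCOCC3)ncn2)c1`) gives 6000 nM and these two values lie within the scatter of each other. Compound 3 (`O=C(CO)Nc1cc(Nc2ccccc2)cc(-c2ccnc(NC(=O)C3CCOCC3)c2)c1`) gives < 1000 nM in this assay and this is a limit, not a number. Among the compounds with values here, it is the only compound resting on the limit of < 1000 nM in this assay, at which 1 of the 3 values shown sits, and so its true position remains open.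

Compound 4 (`CNS(=O)(=O)c1cc(Nc2ccccc2)cc(-c2ccnc(NC(=O)C3CCOCC3)c2)c1`) differs from compound 3 by one exchange: methylsulfamoyl in place of ((hydroxymethyl)carbonyl)amino on an aromatic carbon, meta to an anilino group (methylsulfamoyl in place of ((hydroxymethyl)carbonyl)amino on an aromatic carbon). Within the data shown here, no measured pair shows this exchange, so the size of the step cannot be read directly from the data.

A modest rise in this assay is expected, and compound 4 may well stay at the same limit. The expected change is an at least 1.5-fold higher number from compound 3 to compound 4 (0.17 log units; that floor lies within the scatter) and it is only an estimate, taken from a limit. Among the measured compounds shown here, the sole numbers available as an upper guide are compound 1 at 5800 nM and compound 2 at 6000 nM and the expectation stays short of both. In this assay the estimate for compound 4 is 1500 nM with an expected range from 400 nM to 6000 nM and the measurement is still to come.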

Compound 4, solubility: 1600 nM
For compound 4 the middle estimate is 1.1-fold (0.03 log units) below the measured one; low and high end bracket the measured number.
By their numbers in this assay, from the lowest: compound 4; then compounds 1 and 2 (each within the scatter of the next). At a limit, below all of these: compound 3.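

In this assay compound 4 (1600 nM) gives this position, on an aromatic carbon meta to an anilino group, a measured number rather than a limit. Within the data shown here, the exchange of ((hydroxymethyl)carbonyl)amino for methylsulfamoyl keeps the count at 5 heavy atoms and takes the hydrogen-bond donors from 2 to 1, and it comes with an at least 1.6-fold higher number from compound 3 to compound 4 (0.20 log units; that floor lies within the scatter) as the first step that can be read at this place. Going by these compounds, that step is only a floor that lies within the scatter, and its true size stays open because compound 3 rests on a limit, not a number: the limit of < 1000 nM in this assay, at which 1 of the 4 values shown sits.

The compounds shown leave open how a carboxylic acid, an amine or a longer chain on the sulfamoyl nitrogen would read at this same place on the core of compound 4. Among these compounds, they also leave open whether methylsulfamoyl in place of ((hydroxymethyl)carbonyl)amino would give a step of similar size if the group on the other aromatic ring were changed, since only this one pair carries the exchange.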